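Replacing 6-bromopyridin-2-yl with 1H-indazol-6-yl on the shared core

The source may hold more compounds than are shown below. What is called first, only, known or untested is meant among the compounds shown, and "the series" means these compounds.

Of the compounds shown here, three sharing one core have been measured in an ADME assay on A549 cells (Homo sapiens) for cytotoxicity, read by resazurin assay, with a stated time of 48 h; a higher number here means that more compound is tolerated, a lower number that less compound is tolerated. Compound 1 (`O=C(Nc1ccc(NCC2CCCC2)cc1Cl)c1cc(Cl)ccc1O`) gives 21500 nM, compound 2 (`O=C(Nc1ccc(NCc2ccc(Cl)cc2)cc1Cl)c1cc(Cl)ccc1O`) gives 59700 nM and compound 3 (`O=C(Nc1ccc(NCc2cccc(Br)n2)cc1Cl)c1cc(Cl)ccc1O`) gives 92300 nM. Compound 3 thus stands at the upper end of the three, but its nearest neighbour is close, with a 1.5-fold higher number from compound 2 to compound 3 (0.19 log units; within the scatter). The two steps from the cyclopentyl group to an aromatic group are larger, at a 2.8-fold higher number from compound 1 to compound 2 (0.44 log units; beyond the scatter) and a 4.3-fold higher number from compound 1 to compound 3 (0.63 log units; beyond the scatter).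

Compound 4 (`O=C(Nc1ccc(NCc2ccc3cn[nH]c3c2)cc1Cl)c1cc(Cl)ccc1O`) changes the group on a saturated chain carbon bound to a nitrogen on an aromatic ring: 1H-indazol-6-yl in place of 6-bromopyridin-2-yl on a saturated chain carbon bound to a nitrogen on an aromatic ring. The incoming 1H-indazol-6-yl is aromatic, like the two groups that gave the higher numbers, so the exchange between those two, a 1.5-fold higher number from compound 2 to compound 3 (0.19 log units; within the scatter), is the closest guide. Among the measured compounds shown here, no measured compound carries a five-membered aromatic ring in this place, which leaves the outcome open towards the cyclopentyl level of compound 1 at 21500 nM. A slightly lower number is therefore expected in this assay, but no step beyond the scatter. The expected step is a 1.7-fold lower number from compound 3 to compound 4 (0.22 log units; within the scatter). For compound 4 the estimated value is 55000 nM, with an expected range from 20000 nM to 120000 nM.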

Compound 4, half-maximal cytotoxic concentration: 45300 nM
Compound 4: middle estimate off by 1.2-fold (0.08 log units), on the high side; measured number inside the range.
By their numbers in this assay, from the lowest: compound 1; then compounds 4, 2 and 3 (each within the scatter of the next, the first and the last beyond it).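

The 1H-indazol-6-yl group, the only group shown at this place with a five-membered aromatic ring or a hydrogen-bond donor, separates from 6-bromopyridin-2-yl in this assay, with a 2.0-fold lower number from compound 3 to compound 4 (0.31 log units; beyond the scatter), so the aromatic groups at this place do not all give one level. Against 4-chlorophenyl there is no such separation, with a 1.3-fold lower number from compound 2 to compound 4 (0.12 log units; within the scatter), yet the group stays clear of cyclopentyl, with a 2.1-fold higher number from compound 1 to compound 4 (0.32 log units; beyond the scatter), and so all three aromatic groups shown on the saturated chain carbon give higher numbers than the cyclopentyl of compound 1, with no compound shown going against this. No measurement offered here bears on why the numbers fall in this order.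

The compounds shown leave open whether the result follows the hydrogen on the indazole nitrogen or the fused ring system as a whole, a question that a 1-methyl-1H-indazol-6-yl group or a single pyrazole ring at this place could separate. They also leave open how this place responds to a group that is not a ring carbon framework alone, such as an aminomethyl or a carboxylic acid on the aromatic ring, or to a longer chain before that ring.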